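The source may hold more compounds than are shown below. What is called first, only, known or untested is meant among the compounds shown, and "the series" means these compounds.

Compound 1 `O=S(=O)(NCCCNCc1ccccc1Cl)c1cc(C(F)(F)F)cc(C(F)(F)F)c1` carries a 2-chlorophenyl group on a saturated chain carbon bound to an amine nitrogen. Among the compounds with values here, in a functional assay on HT-29 cells (Homo sapiens) for inhibition, read by MTT assay, with a stated time of 72 h (on this read-out lower numbers stand for stronger inhibition of growth and higher numbers for weaker inhibition of growth), compound 1 gives 20000 nM, the highest of the three numbers measured so far. Compound 3 `O=S(=O)(NCCCNCc1ccc(Cl)c(Cl)c1)c1cc(C(F)(F)F)cc(C(F)(F)F)c1` gives 4700 nM in this assay, and compound 2 `O=S(=O)(NCCNCc1ccc(-c2ccccc2)cc1)c1cc(C(F)(F)F)cc(C(F)(F)F)c1` gives 2700 nM.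

Within the data shown here, the one single-point step in this set runs a 4.3-fold lower number from compound 1 to compound 3 (0.63 log units; beyond the scatter). Compound 2 differs from compound 1 in more than one place, so its value can only be set beside the others without a step being drawn.

Compound 4 `O=S(=O)(NCCCNCC1COc2ccccc2O1)c1cc(C(F)(F)F)cc(C(F)(F)F)c1` is not yet measured. Its difference from compound 1 is 2,3-dihydro-1,4-benzodioxin-2-yl in place of 2-chlorophenyl on a saturated chain carbon bound to an amine nitrogen. Among the measured compounds shown here, no measured step shows this exact replacement; the only step that bears on it is the change away from 2-chlorophenyl in a 4.3-fold lower number from compound 1 to compound 3 (0.63 log units; beyond the scatter), which gave a modest lower number, and compound 2 with a different aromatic group also sits well below compound 1.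

On that basis compound 4 is expected to give a lower number than compound 1, of modest size and possibly no further than the edge of the scatter, an estimated step of a 2.2-fold lower number from compound 1 to compound 4 (0.35 log units; beyond the scatter). The estimate for compound 4 in this assay is 9000 nM, with a range from 3000 nM to 30000 nM.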

Compound 4, concentration for 50% growth inhibition: 2200 nM
Estimate against measurement, compound 4: 4.1-fold (0.61 log units) above, outside the stated range (below it).
By their numbers in this assay, from the lowest: compounds 4, 2 and 3 (each within the scatter of the next, the first and the last beyond it); then compound 1.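

At the place on a saturated chain carbon bound to an amine nitrogen, this assay shows a 9.1-fold lower number from compound 1 to compound 4 (0.96 log units; beyond the scatter) for the change from 2-chlorophenyl to 2,3-dihydro-1,4-benzodioxin-2-yl, and the same group also goes past 3,4-dichlorophenyl, with a 2.1-fold lower number from compound 3 to compound 4 (0.33 log units; beyond the scatter). The earlier step had only exchanged one chlorinated phenyl group for another, whereas this result shows that the number at this place can also fall with a group that holds a six-membered non-aromatic ring with 2 hetero atoms and carries 2 hydrogen-bond acceptors. Nothing available gives a reason for the size of these steps, so the result cannot be traced to any one feature of the entering group.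

The compounds shown leave open whether both ring oxygens of the 2,3-dihydro-1,4-benzodioxin-2-yl group matter, which a chroman-2-yl group with its single ring oxygen or an open 2-methoxyphenyl group at the same place could test. They also leave open whether the step from compound 1 to compound 4 would carry over to a longer chain between the sulfonamide nitrogen and the amine.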